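Tert-Butyl for Chloro in a Hydroxamic Acid Series

The source may report more compounds than this note shows. Statements on the series, on what has been measured and on what is new or still open speak of the compounds shown alone.

Compound 1, `O=C(CCC1=CCN(CCCc2ccc(Cl)cc2)C1=O)NO`, gives 3330 nM.
Compound 2, `CC(C)(C)c1ccc(CCCN2CC=C(CCC(=O)NO)C2=O)cc1`, gives 3330 nM.
Compound 3, `O=C(CCC1=CCN(Cc2ccc(Cl)cc2)C1=O)NO`, gives 3330 nM.

These three compounds were measured in a functional assay on ACHN cells (Homo sapiens) for inhibition, read by sulforhodamine B assay; a lower number here means a stronger inhibitor of growth, a higher number a weaker inhibitor of growth. Compound 1 and compound 2 differ in one place, (tert-butyl in place of chloro on an aromatic carbon), and the step is no change at the digits printed from compound 1 to compound 2 (within the scatter). Compound 3 shares the hydroxamic acid and the lactam with compound 1, but how the two cores differ is not broken down here; its value lies within the scatter of compound 1 and of compound 2.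

Compound 4, `CC(C)(C)c1ccc(CN2CC=C(CCC(=O)NO)C2=O)cc1`, is not yet measured. It differs from compound 3 by tert-butyl in place of chloro on an aromatic carbon, the same change as from compound 1 to compound 2, at the same place. Because no change at the digits printed from compound 1 to compound 2 (within the scatter), the step for compound 4 is expected to be no change at the digits printed from compound 3 to compound 4 (within the scatter). Compound 4 is estimated at 3330 nM, between 1500 nM and 7500 nM.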

Compound 4, concentration for 50% growth inhibition: 860 nM
For compound 4 the middle estimate is 3.9-fold (0.59 log units) above the measured one; the measured number lies below the stated range.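

On the core of compound 3, tert-butyl in place of chloro gives a 3.9-fold lower number from compound 3 to compound 4 (0.59 log units; beyond the scatter) in this assay and so marks a difference that the core of compound 1 did not show. The change therefore does not carry over from one core to the other with the same size of step: the same change on two cores in this assay, no change at the digits printed (within the scatter) from compound 1 to compound 2 and a 3.9-fold lower number (0.59 log units; beyond the scatter) from compound 3 to compound 4, 3.9-fold (0.59 log units) apart, beyond the scatter of two such steps. Two pairs cannot show which feature of the cores accounts for this gap, nor how the change would behave on a further core.

The compounds shown leave open whether a methoxy group, a trifluoromethyl group or an amine in the same place would follow chloro or tert-butyl on either core. They also leave open whether the step would survive with a carboxylic acid in place of the hydroxamic acid.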